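The source may report more compounds than this note shows. Statements on the series, on what has been measured and on what is new or still open speak of the compounds shown alone.

Measured compounds in a functional assay on PC-3 cells (Homo sapiens) for inhibition, read by MTT assay, with a stated time of 72 h; on this read-out higher numbers stand for weaker inhibition and lower numbers for stronger inhibition:

compound 1 `Cc1ccc(Cn2cc(CSC(=S)N3CCN(C(=O)OCc4ccccc4)CC3)nn2)cc1`, with > 128000 nM, a limit of the assay.
compound 2 `Cc1ccc(-n2cc(CSC(=S)N3CCN(C(=O)OC(C)(C)C)CC3)nn2)cc1`, with > 128000 nM, a limit of the assay.
compound 3 `COc1cc(Cn2cc(CSC(=S)N3CCNCC3)nn2)cc(OC)c1OC`, with > 128000 nM, a limit of the assay.

Compound 2 stands at the limit, as do the other two measured compounds; this is the limit of > 128000 nM in this assay, at which 3 of the 3 values shown sit. For the measured compounds named here, no pair of measured compounds differs in only one place, so no measured step is available.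

Compound 4 `CC(C)(C)OC(=O)N1CCN(C(=S)SCc2cn(Cc3ccccc3Cl)nn2)CC1` differs from compound 2 by 2-chlorobenzyl in place of 4-methylphenyl on an aromatic nitrogen. Going by the values given here, with every value so far at the limit, no step beyond the usual scatter is expected. Within this assay the expected step is a step that the limit leaves unreadable from compound 2 to compound 4. For compound 4 the estimate is 150000 nM, range 50000 nM to 500000 nM, most likely reported again only as a limit.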

Compound 4, half-maximal inhibitory concentration: 12500 nM
The estimate for compound 4 lay 12-fold (1.08 log units) above the measured number, outside the stated range (below it).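

In this assay, the group on the aromatic nitrogen of the five-membered ring proves able to move the read-out off the limit: 2-chlorobenzyl in place of 4-methylphenyl gives an at least 10-fold lower number from compound 2 to compound 4 (1.01 log units; beyond the scatter). Compound 2 holds only a limit, so the full size of this step stays unread: the limit of > 128000 nM in this assay, at which 3 of the 4 values shown sit.

Open, on these data alone, is whether the chlorine or the benzyl link carries the step. An unsubstituted benzyl or a 2-methoxybenzyl on that nitrogen, with the rest of compound 4 unchanged, would separate the two.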